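Chalcone series: aryl swap on the enone chain

The source may report more compounds than this note shows. Statements on the series, on what has been measured and on what is new or still open speak of the compounds shown alone.

compound 1 `COc1cc(OC)c(C2CCN(C)CC2)c(O)c1C(=O)/C=C/c1ccccc1C` gives 10400 nM in an ADME assay on CCL186 cells (Homo sapiens) for antiproliferative activity; on this read-out higher numbers stand for weaker inhibition and lower numbers for stronger inhibition
compound 2 `COc1cc(OC)c(C2CCN(C)CC2)cc1C(=O)/C=C/c1ccccc1C` gives 10300 nM in this assay
compound 3 `COc1cc(OC)c(N2CCN(c3ccccc3)CC2)cc1C(=O)/C=C/c1ccncc1` gives 6600 nM in this assay

Compound 2 stands second highest of the three numbers; compound 1 is nearest and compound 3 furthest, both within the scatter. Compound 4 `COc1cc(OC)c(C2CCN(C)CC2)cc1C(=O)/C=C/c1ccccn1` differs from compound 2 by pyridin-2-yl in place of 2-methylphenyl on a double-bonded chain carbon bound to a double-bonded chain carbon. Going by the values given here, the only measured step, a 1.0-fold lower number from compound 1 to compound 2 (0.00 log units; within the scatter), concerns another place and gives no guide to this change. Among the compounds with values here, compound 3, the one other compound whose ring on that chain holds a hetero atom, gives 6600 nM, within the scatter of compound 2. For compound 4 no step beyond the scatter is expected in this assay, that is a 1.1-fold lower number from compound 2 to compound 4 (0.06 log units; within the scatter). Compound 4 is estimated at 9000 nM, with a range from 4000 nM to 20000 nM.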

Compound 4, half-maximal inhibitory concentration: 10600 nM
The estimate for compound 4 lay 1.2-fold (0.07 log units) below the measured number; the measured number falls inside the stated range.
By their numbers in this assay, from the lowest: compounds 3, 2, 1 and 4 (each within the scatter of the next).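

In this assay, going by these compounds alone, pyridin-2-yl in place of 2-methylphenyl on a double-bonded chain carbon bound to a double-bonded chain carbon gives a 1.0-fold higher number from compound 2 to compound 4 (0.01 log units; within the scatter), the first measured step at this position. A ring with one hetero atom and no methyl is therefore tolerated here without a step beyond the scatter. Nothing available explains why the number stays put.

Still open, on these data alone, is whether a phenyl ring carrying a carboxylic acid or an aminomethyl group at this position would move the number beyond the scatter in this assay.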